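Cytotoxicity of Two Aminopyrimidines and an Oxazolyl Analogue

The compounds below may be only part of what the source reports. "The series", "measured", "known", "first", "only" and "open" are said of these compounds alone.

Two compounds have numbers in an ADME assay on cells (Homo sapiens) for cytotoxicity, read by polymerase chain reaction, with a stated time of 3 days; a lower number here means that less compound is tolerated, a higher number that more compound is tolerated. Compound 1 `Nc1nc(Cl)c(-c2nc3ccc(Cl)cc3s2)c(N[C@@H]2C[C@H](CO)[C@@H](O)[C@H]2O)n1` gives 16000 nM in this assay, and compound 2 `Cc1nc(NC(C)(C)C)nc(N[C@@H]2C[C@H](CO)[C@@H](O)[C@H]2O)c1-c1nc2ccccc2s1` gives 12000 nM in this assay. Compound 2 has the lowest of the two numbers, but the gap to compound 1 lies within the scatter, so the two stand level.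

Compound 3 `Cc1nc(Nc2ncco2)nc(N[C@@H]2C[C@H](CO)[C@@H](O)[C@H]2O)c1-c1nc2ccccc2s1` differs from compound 2 in one place: 1,3-oxazol-2-yl in place of tert-butyl on a nitrogen on an aromatic ring. For the measured compounds named here, no measured pair shows the effect of such a change here. The step of a 1.2-fold lower number from compound 2 to compound 3 (0.08 log units; within the scatter) is expected to stay within the scatter. Compound 3 is therefore estimated at 10000 nM in this assay, with a range from 3000 nM to 30000 nM.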

Compound 3, half-maximal cytotoxic concentration: > 25000 nM
Compound 3 was reported as a limit (the forecaster's own chance of this, stated with the estimate: 20%); middle value at least 2.5-fold (0.39 log units) from the limit.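

In this assay, 1,3-oxazol-2-yl in place of tert-butyl on a nitrogen on an aromatic ring gives an at least 2.0-fold higher number from compound 2 to compound 3 (0.31 log units; beyond the scatter), the first step shown at this position, and more compound is tolerated. For compound 3, > 25000 nM is a limit of the assay and not a number. The step therefore sets only a minimum for this change, and its full size stays unknown: the limit of > 25000 nM in this assay, at which 1 of the 3 values shown sits.

The compounds shown do not tell whether a phenyl ring or a 1,3-thiazol-2-yl group on this nitrogen would move the number in the same way.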